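Sulfur-Linked Azoles Give Way to a Quinolinyl Ether

The source may hold more compounds than are shown below. What is called first, only, known or untested is meant among the compounds shown, and "the series" means these compounds.

Compound 1 `CC(C)[C@H](NC(=O)COc1cccc2ccccc12)C(=O)N[C@@H](CC(=O)O)C(=O)CSc1nncn1C` — > 200000 nM
Compound 2 `Cc1nnc(SCC(=O)[C@H](CC(=O)O)NC(=O)[C@@H](NC(=O)COc2cccc3ccccc23)C(C)C)s1` — 190000 nM
Compound 3 `CC(C)[C@H](NC(=O)COc1cccc2ccccc12)C(=O)N[C@@H](CC(=O)O)C(=O)CSc1nnnn1-c1ccccc1` — 153000 nM

The three measured compounds share one core and differ only in the heteroaryl group carried on a sulfur. In a functional assay on Jurkat cells (Homo sapiens) for inhibition (on this read-out higher numbers stand for weaker inhibition and lower numbers for stronger inhibition), compound 1 reaches (the limit of > 200000 nM in this assay, at which 1 of the 3 values shown sits), a limit of the assay rather than a number. Compound 3 gives the lowest of the two numbers, and its nearest neighbour is compound 2, yet the step of a 1.2-fold lower number from compound 2 to compound 3 (0.09 log units; within the scatter) lies within the scatter, so no order between them can be claimed. The steps of an at least 1.0-fold lower number from compound 1 to compound 2 (0.02 log units; that floor lies within the scatter) and an at least 1.3-fold lower number from compound 1 to compound 3 (0.11 log units; that floor lies within the scatter) likewise stay within the scatter.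

Compound 4 `CC(C)[C@H](NC(=O)COc1cccc2ccccc12)C(=O)N[C@@H](CC(=O)O)C(=O)COc1cccc2cccnc12` has not been measured. It differs from compound 3 by (quinolin-8-yl)oxy in place of (1-phenyl-1H-tetrazol-5-yl)sulfanyl on a saturated chain carbon bound to a carbonyl carbon. For the measured compounds named here, no measured step exchanges the sulfur-linked group for an oxygen-linked one; the three measured steps only trade one heteroaryl on a sulfur for another, and none of them moved the number beyond the scatter. Going by the values given here, they are the only bearing evidence, and they argue for a small change at most. Compound 4 is therefore expected at 120000 nM, between 30000 nM and 400000 nM. As far as these compounds go, that estimate means a step of a 1.3-fold lower number from compound 3 to compound 4 (0.11 log units; within the scatter), expected to remain within the scatter, though the change itself is untested and a larger move in either direction cannot be excluded.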

Compound 4, half-maximal inhibitory concentration: > 200000 nM
Compound 4 gave a limit, no number; the forecaster's own chance of this, stated with the estimate: 20%; at least 1.6-fold (0.22 log units) between middle value and limit.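

In this assay, compound 4 joins compound 1 in giving a limit rather than a number: the limit of > 200000 nM in this assay, at which 2 of the 4 values shown sit. The earlier steps shown here only traded one heteroaryl on a sulfur for another, whereas this one replaces the linking sulfur with an oxygen and the five-membered aromatic ring with a second six-membered one, on a saturated chain carbon bound to a carbonyl carbon, giving an at least 1.3-fold higher number from compound 3 to compound 4 (0.11 log units; that floor lies within the scatter) and an at least 1.0-fold higher number from compound 2 to compound 4 (0.02 log units; that floor lies within the scatter). Neither floor goes beyond the scatter, so this larger change shows no stronger inhibition and does not separate compound 4 from compound 2 or compound 3, and the step between compound 1 and compound 4 cannot be read.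

The compounds shown do not separate the linking atom from the ring it carries, a question that (quinolin-8-yl)sulfanyl or (1-phenyl-1H-tetrazol-5-yl)oxy at this place would address. Nor do they show whether a group of another kind on this carbon, such as an amine, a fluorine atom or a carboxylic acid, would give a number well clear of the values seen so far.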